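Alkoxy extension on the shared core of compound 2

A few compounds are considered here, and "the series" means these few. Any claim that something is new, unique, unknown or untested is made for them only; others in the source may bear on it.

Compound 1 `Brc1cncc(N2CC[C@@H]3CN[C@@H]3C2)c1` and compound 2 `COc1cncc(N2CC[C@@H]3CN[C@@H]3C2)c1` share one core and differ only at the aromatic substituent. In a functional assay on HEK293 cells for agonist activity at Neuronal acetylcholine receptor; alpha3/beta4 (Homo sapiens), read by FLIPR (on this read-out lower numbers stand for an effect already at smaller amounts and higher numbers for an effect only at larger amounts of compound), compound 1 gives 950 nM, and compound 2 gives 4500 nM. For the measured compounds named here, compound 2 therefore holds the highest of the two numbers in this assay, and the only measured step, a 4.7-fold higher number from compound 1 to compound 2 (0.68 log units; beyond the scatter), leads to it.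

Compound 3 `CCOc1cncc(N2CC[C@@H]3CN[C@@H]3C2)c1` is the next step from compound 2: methyl in place of hydrogen on a saturated chain carbon bound to an oxygen on an aromatic ring, read one bond further out, methoxy to ethoxy. Going by the values given here, no measured step covers a change at the saturated chain carbon bound to the aromatic oxygen; the step from bromo to methoxy concerns the aromatic carbon itself and gives no direct guide to chain extension. With nothing in the series to anchor it, the expectation for this assay is a step of modest size at most, direction uncertain, quite possibly within the scatter.

Compound 3 is accordingly estimated at 6000 nM in this assay, with a range from 2000 nM to 18000 nM. The expected step, a 1.3-fold higher number from compound 2 to compound 3 (0.12 log units; within the scatter), reflects this uncertainty.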

Compound 3, half-maximal effective concentration: 2800 nM
Estimate against measurement, compound 3: 2.1-fold (0.33 log units) above; low and high end bracket the measured number.
By their numbers in this assay, from the lowest: compound 1; then compounds 3 and 2 (each within the scatter of the next).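

In this assay, for the compounds shown here, the change from methoxy to ethoxy gives the first reading at the saturated chain carbon bound to the aromatic oxygen: a 1.6-fold lower number from compound 2 to compound 3 (0.21 log units; within the scatter), so the added methyl does not separate the two alkoxy compounds on this read-out. Against bromo, the ethoxy group gives a 2.9-fold higher number from compound 1 to compound 3 (0.47 log units; beyond the scatter), which sits alongside a 4.7-fold higher number from compound 1 to compound 2 (0.68 log units; beyond the scatter), so both alkoxy groups shown carry higher numbers than bromo on the shared core. Compound 1 therefore keeps the lowest number of the three, with its steps to both others beyond the scatter, while this aromatic position tolerates one more carbon on the alkoxy chain without a change that can be read. No supporting data are available to explain these differences.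

From the compounds shown here alone, it remains open whether a longer chain, such as propoxy, or a branched isopropoxy group would also stay within the scatter of methoxy and ethoxy. Also open, going by these compounds, is whether an amine or chloro at the aromatic carbon would give a number closer to that of bromo or closer to those of the alkoxy compounds.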